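A few compounds are considered here, and "the series" means these few. Any claim that something is new, unique, unknown or untested is made for them only; others in the source may bear on it.

Measured compounds:
- compound 1, `COc1cc2c(cc1OC)C(=O)/C(=C/c1cc(C)cc(C)c1)CC2`: 4000 nM
- compound 2, `COc1cc2c(cc1OC)C(=O)/C(=C/c1cc(C)c(O)c(C)c1)CC2`: 4800 nM
- compound 3, `COc1cc2c(cc1OC)C(=O)/C(=C/c1cccc(C)c1)C2`: 1800 nM

All three values come from a functional assay on Jurkat cells (Homo sapiens) for antiproliferative activity, read by MTT assay; a higher number here means a weaker inhibitor, a lower number a stronger inhibitor. Compound 1 and compound 2 share one core; compound 3 has a different core, and the difference between the two cores is not broken down here. In this assay compound 3 gives the lowest number of the three, and its nearest neighbour, compound 1, stands at 4000 nM.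

The change from compound 1 to compound 2 is hydroxy in place of hydrogen on an aromatic carbon, and it made a step of a 1.2-fold higher number from compound 1 to compound 2 (0.08 log units; within the scatter).

Compound 4, `COc1cc2c(cc1OC)C(=O)/C(=C/c1ccc(O)c(C)c1)C2`, is not yet measured. It differs from compound 3 by hydroxy in place of hydrogen on an aromatic carbon. This is the same kind of change as that from compound 1 to compound 2, not the same: in compound 2 the hydroxy sits ortho to two methyl groups, in compound 4 ortho to a methyl group.

Within the data shown here, the expectation rests on the single earlier step, a 1.2-fold higher number from compound 1 to compound 2 (0.08 log units; within the scatter), which lay within the scatter; for compound 4 a step of similar size, a 1.2-fold higher number from compound 3 to compound 4 (0.07 log units; within the scatter), is therefore expected. Compound 4 is estimated at 2100 nM, with a range from 1000 nM to 4500 nM.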

Compound 4, half-maximal inhibitory concentration: 1160 nM
Compound 4: the middle estimate sits 1.8-fold (0.26 log units) above what was measured; the measured number falls inside the stated range.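

In this assay, hydroxy in place of hydrogen on an aromatic carbon gives a 1.6-fold lower number from compound 3 to compound 4 (0.19 log units; within the scatter), so on the core of compound 3, as on the core of compound 1, the change leaves the number within the scatter. Set side by side, the two steps show no difference between the cores: the same change on two cores in this assay, a 1.2-fold higher number (0.08 log units; within the scatter) from compound 1 to compound 2 and a 1.6-fold lower number (0.19 log units; within the scatter) from compound 3 to compound 4, 1.9-fold (0.27 log units) apart, within the scatter of two such steps. This supports carrying the change between these two cores without expecting a clear shift in the number, but it rests on a single pair for each core, neither step establishes an effect of the hydroxy in either direction, and nothing here extends to any further core.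

Open, on these data alone, is what a methoxy, an amine or a carboxylic acid at the same aromatic carbon would do in this assay, and whether any of them would give a step beyond the scatter. Also open, as far as these compounds go, is whether the hydroxy step would stay this small on a third core.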